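The compounds below may be only part of what the source reports. "The series", "measured", "known", "first", "only" and "open" are said of these compounds alone.

Of the compounds shown here, two built on one shared core have been measured in a functional assay on CHO cells for positive allosteric modulation of metabotropic glutamate receptor 2 (Homo sapiens), read by scintillation counting and GTPgammaS binding, with a stated time of 30 min; a lower number here means that less compound is needed, a higher number that more compound is needed for the effect. Compound 1 `Cc1ncccc1Oc1ccc(-c2ccn(CC3CC3)c(=O)c2C#N)cc1` gives 1070 nM. Compound 2 `Cc1ccc(Oc2ccc(-c3ccn(CC4CC4)c(=O)c3C#N)cc2)c(C)n1` gives 263 nM. Within the data shown here, the single measured step between them, a 4.1-fold lower number from compound 1 to compound 2 (0.61 log units; beyond the scatter), comes from methyl in place of hydrogen on an aromatic carbon. Of the two numbers, compound 2 stands lowest, with compound 1 the nearest at a higher number.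

Compound 3 `Cc1ccc(Oc2ccc(-c3ccn(CC4CC4)c(=O)c3C#N)cc2Cl)c(C)n1` has not yet been measured. It differs from compound 2 in one place: chloro in place of hydrogen on an aromatic carbon. The chloro enters on a six-membered aromatic ring of carbon only, ortho to a (2,6-dimethylpyridin-3-yl)oxy group and meta to a large group.

Among the measured compounds shown here, no measured step tests a chloro at this place. For the measured compounds named here, the only step available, a 4.1-fold lower number from compound 1 to compound 2 (0.61 log units; beyond the scatter), concerns a different group on a different ring and shows merely that a small addition on an aromatic carbon can move the number; it gives no firm direction for compound 3. For compound 3 the expected change is a 1.5-fold lower number from compound 2 to compound 3 (0.16 log units; within the scatter), a step that may not rise beyond the scatter. Compound 3 is therefore estimated at 180 nM, with a likely range from 60 nM to 600 nM.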

Compound 3, half-maximal effective concentration: 64 nM
Estimate against measurement, compound 3: 2.8-fold (0.45 log units) above; measured number inside the range.
By their numbers in this assay, from the lowest: compound 3; then compound 2; then compound 1.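

In this assay, chloro in place of hydrogen on an aromatic carbon, ortho to the (2,6-dimethylpyridin-3-yl)oxy group, gives a 4.1-fold lower number from compound 2 to compound 3 (0.61 log units; beyond the scatter). Among these compounds, this is the first sign that the six-membered aromatic ring of carbon only responds to a change at this place, and that a single added chlorine atom here lowers the number rather than raising it. The earlier step, a 4.1-fold lower number from compound 1 to compound 2 (0.61 log units; beyond the scatter), came from a methyl on a different ring, so two separate places in this series have now each moved the number beyond the scatter, though nothing shown gives a reason for the effect of the chloro.

From the compounds shown here alone, it remains open whether the lower number belongs to chloro itself or would also follow from a fluoro, a methyl or a methoxy on the same carbon. It is equally open whether a chloro on another carbon of this ring would act in the same way, since only this one place is covered by the compounds shown.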